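Notes on the isobutylamino to isopropylamino step

The compounds below may be only part of what the source reports. "The series", "measured", "known", "first", "only" and "open" are said of these compounds alone.

Measured in a functional assay on RAW264.7 cells (Mus musculus) for inhibition, read by Griess assay, with stated times of 1 h and 24 h (on this read-out lower numbers stand for stronger inhibition and higher numbers for weaker inhibition), as follows
compound 1 `CCCc1nn(C)c2c(NCC(C)C)nc(/C=C/c3ccccc3)nc12` gives 22100 nM
compound 2 `CCCc1nn(C)c2c(N3CCCC3)nc(-c3cc(OC)c(OC)c(OC)c3)nc12` gives "not active" (no number reported)

Going by the values given here, compound 1 at 22100 nM holds the only number in the set, and compound 2 gave none. Compound 3 `CCCc1nn(C)c2c(NC(C)C)nc(/C=C/c3ccccc3)nc12` carries isopropyl in place of isobutyl on a nitrogen on an aromatic ring, with isopropyl in place of isobutyl on a nitrogen on an aromatic ring as the counted difference. No measured step among these compounds sizes this change, so in this assay no shift beyond the scatter is expected in either direction. The estimated 1.1-fold higher number from compound 1 to compound 3 (0.05 log units; within the scatter) is expected to stay small. Compound 3 is estimated at 25000 nM with a range from 11000 nM to 55000 nM as the expected bounds.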

Compound 3, half-maximal inhibitory concentration: 12200 nM
For compound 3 the middle estimate is 2.0-fold (0.31 log units) above the measured one, within the range that was stated.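

In this assay, the step at this nitrogen gives a first size for the change: a 1.8-fold lower number from compound 1 to compound 3 (0.26 log units; within the scatter). Isopropyl in place of isobutyl therefore leaves the number within the usual scatter, and compound 3 keeps a measurable inhibition value, so this single pair shows no clear effect of the change. Nothing available gives a reason for this result.

From the compounds shown here alone, whether a longer chain such as n-hexyl, or a chain ending in a carboxylic acid, would move the number beyond the scatter remains open. So does the outcome of a cyclohexyl group on the same nitrogen.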